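Fluorine shift on the benzyl group: expected cytotoxicity

The source may hold more compounds than are shown below. What is called first, only, known or untested is meant among the compounds shown, and "the series" means these compounds.

Working notes on three measured compounds and one awaiting measurement. In an ADME assay on MT4 cells (Homo sapiens) for cytotoxicity, read by MTT assay (a higher number here means that more compound is tolerated, a lower number that less compound is tolerated), compound 1 `CCOC(=O)/C(O)=C/C(=O)c1cn(Cc2ccc(F)c(F)c2)c2cccc(OC)c12` gives 125000 nM, the highest of the three numbers recorded. Compound 2 `COc1cccc2c1c(C(=O)/C=C(\O)C(=O)O)cn2Cc1ccccc1F` gives 70500 nM in this assay, a gap to compound 1 that lies within the scatter, and compound 3 `COc1cccc2c1c(C(=O)/C=C(\O)C(=O)O)cn2Cc1ccc(F)cc1` gives 41100 nM, which sits beyond the scatter from compound 1.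

Compound 4 `CCOC(=O)/C(O)=C/C(=O)c1cn(Cc2c(F)cccc2F)c2cccc(OC)c12` is not yet measured. It differs from compound 1 as follows: 2,6-difluorophenyl in place of 3,4-difluorophenyl on a saturated chain carbon bound to an aromatic nitrogen. The atoms are the same; only the placement of the two fluorine substituents on the ring changes.

For the measured compounds named here, the one measured step that bears on a fluorine shift around this ring is a 1.7-fold lower number from compound 2 to compound 3 (0.23 log units; within the scatter), which moves a single fluorine from one ring position to another and stays within the scatter. Nothing measured speaks to two fluorines moving at once, so the comparison is indirect, but the available evidence gives no reason to expect a step beyond the scatter in either direction.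

Compound 4 is therefore expected to land close to compound 1, with an estimated step of a 1.1-fold lower number from compound 1 to compound 4 (0.06 log units; within the scatter). The estimate for compound 4 is 110000 nM, with a range from 50000 nM to 250000 nM.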

Compound 4, half-maximal cytotoxic concentration: 63400 nM
Compound 4: middle estimate off by 1.7-fold (0.24 log units), on the high side; low and high end bracket the measured number.
By their numbers in this assay, from the lowest: compounds 3, 4, 2 and 1 (each within the scatter of the next, the first and the last beyond it).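

In this assay the shift from 3,4-difluorophenyl to 2,6-difluorophenyl on a saturated chain carbon bound to an aromatic nitrogen gives a 2.0-fold lower number from compound 1 to compound 4 (0.29 log units; within the scatter) and so stays inside the scatter, though close to its edge. For the compounds shown here, this is the first measured step at this place in which both fluorines move together, and the first on the ethyl ester; the only earlier step, a 1.7-fold lower number from compound 2 to compound 3 (0.23 log units; within the scatter), moved a single fluorine with a carboxylic acid in the molecule, and the two steps together show this place tolerating fluorine shifts without a step beyond the scatter in either form of the series. No measurement on hand accounts for the size of this step.

The compounds shown leave open whether anything other than fluorine on the ring, such as chlorine, a methyl group or an unsubstituted benzyl, would give a step beyond the scatter at this place. They also pair no ethyl ester with a carboxylic acid carrying the same benzyl group, so the effect of that exchange on the number in this assay cannot be read.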